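Swapping a Piperazine Arm for a Piperidine Ring

The source may report more compounds than this note shows. Statements on the series, on what has been measured and on what is new or still open speak of the compounds shown alone.

Of the compounds shown here, two have so far been measured in an ADME assay on microsomes from liver (Homo sapiens) for metabolic stability, read by LC-MS, with a stated time of 10 min, tested at 0.5 uM; on this read-out lower numbers stand for a less stable compound and higher numbers for a more stable compound. Compound 1, `c1cnc2c(c1)CCC[C@@H]2N(CCCN1CCNCC1)Cc1nc2ccccc2[nH]1`, gives 63% in this assay. Compound 2, `CCN1CCN(CCCN(C[C@H]2Cc3ccccc3CN2)[C@H]2CCCc3cccnc32)CC1`, gives 59% in this assay. These two values lie within the usual scatter of each other, so on the numbers shown compound 2 cannot be told apart from compound 1; the two sit in the same region of this assay.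

Compound 3, `c1ccc2c(c1)CN[C@@H](CN(CC[C@@H]1CCCNC1)[C@H]1CCCc3cccnc31)C2`, has not yet been measured. Compared with compound 2 it carries a single change: piperidin-3-yl in place of (4-ethylpiperazin-1-yl)methyl on a saturated chain carbon, two bonds along the chain from an amine nitrogen. Among the measured compounds shown here, no measured pair in this set shares this change, so there is no step to lean on, and the only guide is that both measured compounds cluster closely in this assay.

The expected step is a number 1 percentage points lower from compound 2 to compound 3 (within the scatter), which means no change beyond the scatter in either direction. Compound 3 is estimated to give 58% in this assay, with a range from 35% to 80% that reflects how little the two measured compounds reveal about this particular change.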

Compound 3, percent of the compound remaining: 75%
The estimate for compound 3 lay 17 percentage points below the measured number, and the stated range covers the measured number.
By their numbers in this assay, from the lowest: compounds 2 and 1 (each within the scatter of the next); then compound 3.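

In this assay, piperidin-3-yl in place of (4-ethylpiperazin-1-yl)methyl, on a saturated chain carbon, two bonds along the chain from an amine nitrogen, gives a number 16 percentage points higher from compound 2 to compound 3 (beyond the scatter). Among the compounds shown here, this shows that the read-out can respond to what sits at this position, something compounds 1 and 2 could not show, as they differ in more than one place and no step links them; the change is also several changes at once, with 6 heavy atoms entering for 9, one ring nitrogen for two, a hydrogen-bond donor where the leaving group has none, and a new defined stereocentre. No measurement shown here explains why the number moved.

For the compounds shown here, the single step cannot separate these differences, so it remains open whether the ethyl group, the second ring nitrogen or the way the ring is attached accounts for the result. Also open, on these data alone, is how a morpholine ring, a simple dimethylamino group or a longer chain carrying the piperidine ring would read at this position, and whether the opposite stereocentre on the piperidin-3-yl group would give a similar number.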